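A few compounds are considered here, and "the series" means these few. Any claim that something is new, unique, unknown or untested is made for them only; others in the source may bear on it.

Two compounds of this series carry a reading in an ADME assay on HepG2 cells (Homo sapiens) for cytotoxicity, read by CellTiter-Glo and resazurin assay, with a stated time of 72 h; on this read-out higher numbers stand for an effect only at larger amounts of compound and lower numbers for an effect already at smaller amounts. Compound 1 `CCOc1cccc(-c2ccc(C(=O)N(Cc3cccc(OCCCCCC(=O)O)c3)C(C)C)cc2)c1` bears the free acid chain. In this assay compound 1 gives > 20800 nM, which is a limit of the assay and not a number. Compound 2 `CCOC(=O)CCCCCOc1cccc(CN(C(=O)c2ccc(-c3ccc4ccccc4c3)cc2)C(C)C)c1` is the ethyl ester with a naphthalen-2-yl group on the shared core. In this assay compound 2 gives > 26000 nM, again a limit of the assay rather than a measured number. Within the data shown here, both readings therefore rest at the top of the tested range, the limit of > 20800 nM in this assay, at which 1 of the 2 values shown sits, and (the limit of > 26000 nM in this assay, at which 1 of the 2 values shown sits), so compound 2 stands level with compound 1 as far as the numbers go, and no step between measured compounds can be resolved.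

Compound 3 `CCOC(=O)CCCCCOc1cccc(CN(C(=O)c2ccc(-c3ccco3)cc2)C(C)C)c1` differs from compound 2 in one place: furan-2-yl in place of naphthalen-2-yl on an aromatic carbon. Among the measured compounds shown here, no measured pair shows what such a change does on this read-out. The step from compound 2 to compound 3 is expected to be a number no higher from compound 2 to compound 3 (the limit leaves the size open), nothing beyond the scatter. Compound 3 is expected to come out near 26000 nM, within 8000 nM to 50000 nM, and most likely again reported only as a limit.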

Compound 3, half-maximal effective concentration: > 26000 nM
Compound 3: no number, only a limit; the forecaster's own chance of this, stated with the estimate: 75%; the middle value sits exactly at the limit.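

No step can be read from compound 2 to compound 3, because each of the two readings in this assay is a limit of the assay and not a number: the limit of > 26000 nM in this assay, at which 2 of the 3 values shown sit.

The compounds shown leave open at what concentration any of them would give an effect in this assay, and whether furan-2-yl in place of naphthalen-2-yl alters the read-out.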